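The source may report more compounds than this note shows. Statements on the series, on what has been measured and on what is new or still open speak of the compounds shown alone.

Measured compounds:
Compound 1 `CC1=C(C(=O)C2CC2)C(c2ccoc2)NC(=O)N1`: 16%
Compound 2 `CC1=C(C(=O)C2CC2)C(c2cccs2)NC(=O)N1`: 15%
Compound 3 `CC1=C(C(=O)C2CC2)C(c2ccsc2)NC(=O)N1`: 1%

All three share one core and differ only in the ring attached to the saturated ring carbon. In an assay on membranes from HeLa cells for displacement of a labelled ligand from adenosine receptor A3 (Homo sapiens), read by scintillation counting, with a stated time of 180 min, tested at 1 uM (on this read-out lower numbers stand for less inhibition and higher numbers for more inhibition at the one concentration tested (going by the name of the read-out)), compound 2 gives 15%, the second highest of the three numbers. Its nearest neighbour is compound 1, and the step of a number 1 percentage points lower from compound 1 to compound 2 (within the scatter) lies within the scatter, so the two cannot be told apart. The step of a number 14 percentage points lower from compound 2 to compound 3 (beyond the scatter) is beyond the scatter and modest.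

Compound 4 `CCSC(=O)C1=C(C)NC(=O)NC1c1cccs1` has not been measured. It differs from compound 2 at a different place than any measured step: ethylsulfanyl in place of cyclopropyl on a carbonyl carbon. None of the three measured steps touches the carbonyl carbon, so none of them bears on this change, and there is no basis for expecting a step in either direction beyond the scatter.

The estimate therefore rests on compound 2 alone: compound 4 is expected to show 15% in this assay, within 0% to 35%, which means an expected step of no change at the digits printed from compound 2 to compound 4 (within the scatter).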

Compound 4, a percentage reported as inhibition, at one concentration (the size of the read-out at that concentration, not a potency): 1%
Compound 4: middle estimate off by 14 percentage points, on the high side, within the range that was stated.
By their numbers in this assay, from the lowest: compounds 3 and 4 (each within the scatter of the next); then compounds 2 and 1 (each within the scatter of the next).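

In this assay, the group on the carbonyl carbon proves able to move the number: ethylsulfanyl in place of cyclopropyl gives a number 14 percentage points lower from compound 2 to compound 4 (beyond the scatter). The earlier compounds shown here all carry cyclopropyl there, so they could not show this. The change swaps a three-membered carbon ring for an open chain containing sulfur, with the same count of heavy atoms, so matching that count at this place does not keep the number unchanged. Nothing available here explains the step.

The compounds shown leave open whether the step goes with losing the ring or with gaining the sulfur. They also leave open how an ethyl or ethoxy group would read on the same carbonyl carbon, and whether the step holds with furan-3-yl on the saturated ring carbon.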